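Replacing the fused-ring chloro: a 1-hydroxyethyl analogue

This account rests on a few compounds, and the source may have more. Where it says the series, first, only, none or still open, it means among the compounds named here.

Compound 1 `CC(=O)NCc1cccc(Cn2nc(NS(=O)(=O)c3ccc(Cl)s3)c3c(Cl)cccc32)c1` gives 31.6 nM in a functional assay on CHO cells for antagonist activity at C-C chemokine receptor type 4 (Homo sapiens), read by GTPgammaS binding (a lower number here means a stronger inhibitor, a higher number a weaker inhibitor), the lowest of the three numbers in hand. Compound 2 `CC(=O)NCc1cccc(Cn2nc(NS(=O)(=O)c3ccc(Cl)s3)c3c(C#N)cccc32)c1` gives 316 nM and compound 3 `CC(=O)NCc1cccc(Cn2nc(NS(=O)(=O)c3ccc(Cl)s3)c3c(C(C)=O)cccc32)c1` gives 100 nM. Both replacements of the chloro on the same aromatic carbon raised the number: a 10-fold higher number from compound 1 to compound 2 (1.00 log units; beyond the scatter) and a 3.2-fold higher number from compound 1 to compound 3 (0.50 log units; beyond the scatter). Compound 4 `CC(=O)NCc1cccc(Cn2nc(NS(=O)(=O)c3ccc(Cl)s3)c3c(C(C)O)cccc32)c1` carries 1-hydroxyethyl in place of chloro on an aromatic carbon. The measured step that bears most on it is a 3.2-fold higher number from compound 1 to compound 3 (0.50 log units; beyond the scatter), acetyl being the nearest of the measured groups to 1-hydroxyethyl; the cyano step is larger but less alike. A modest rise is therefore expected, a 4.0-fold higher number from compound 1 to compound 4 (0.60 log units; beyond the scatter), within the spread of the two measured steps. Compound 4 is estimated at 125 nM in this assay, with a range of 40 nM to 400 nM.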

Compound 4, half-maximal inhibitory concentration: 20 nM
For compound 4 the middle estimate is 6.3-fold (0.80 log units) above the measured one, outside the stated range (below it).
By their numbers in this assay, from the lowest: compounds 4 and 1 (each within the scatter of the next); then compound 3; then compound 2.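

Chloro is not the only group that holds the number at this aromatic carbon: 1-hydroxyethyl gives a 1.6-fold lower number from compound 1 to compound 4 (0.20 log units; within the scatter) and so stays level with it, whereas acetyl and cyano do not. Groups other than chloro also separate widely here, with a 5.0-fold lower number from compound 3 to compound 4 (0.70 log units; beyond the scatter) and a 16-fold lower number from compound 2 to compound 4 (1.20 log units; beyond the scatter) in the same series. No measurement at hand accounts for these gaps.

As far as these compounds go, whether the hydroxyl itself is what counts stays open, and 1-methoxyethyl, hydroxymethyl or an aminomethyl group on this carbon would address that. From the compounds shown here alone, compound 4 is drawn without defined configuration, so the separate contributions of its two mirror forms also remain unknown.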